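The source may report more compounds than this note shows. Statements on the series, on what has been measured and on what is new or still open speak of the compounds shown alone.

Measured in an ADME assay on MCF7-DOX cells (Homo sapiens) for cytotoxicity, read by MTT assay, with a stated time of 48 h; on this read-out higher numbers stand for weaker inhibition and lower numbers for stronger inhibition:
- Compound 1 `CCCc1c(OC)cc(OC)c(C(=O)/C=C/c2cccc(N3CCNCC3)c2)c1O`: > 100000 nM
- Compound 2 `COc1cc(O)c(C(=O)/C=C/c2cccc(N3CCN(C)CC3)c2)c(OC)c1`: 62200 nM
- Compound 3 `COc1cc(OC)c(C(=O)/C=C/c2cccc(Cl)c2)c(O)c1CC=C(C)C`: 59500 nM

The value of compound 1 is a limit of the assay and not a number. It marks the top of what this assay reports here, and (the limit of > 100000 nM in this assay, at which 1 of the 3 values shown sits). Its true position is therefore unknown, and any comparison starting from it is loose.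

Compound 4 `COc1cc(OC)c(C(=O)/C=C/c2cccc(N3CCNCC3)c2)c(O)c1C` has not yet been measured. It keeps the core of compound 1 and changes in one place: hydrogen in place of ethyl on a saturated chain carbon bound to an aromatic carbon. In words, this is hydrogen in place of ethyl on a saturated chain carbon bound to an aromatic carbon, so the propyl chain of compound 1 becomes a methyl.

Among the measured compounds shown here, no measured pair shows what this change alone does. Compound 2 and compound 3 each differ from compound 1 in more than one place. Even so, compound 2 at 62200 nM and compound 3 at 59500 nM show the level that measurable members of this small set reach.

A small step towards stronger inhibition is expected, an at least 1.2-fold lower number from compound 1 to compound 4 (0.09 log units; that floor lies within the scatter), and it may not exceed the scatter. Compound 4 may also turn out to be reported only as a limit. For compound 4 the estimated value is 80000 nM, with an expected range of 35000 nM to 150000 nM.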

Compound 4, half-maximal inhibitory concentration: 98700 nM
The estimate for compound 4 lay 1.2-fold (0.09 log units) below the measured number; low and high end bracket the measured number.
By their numbers in this assay, from the lowest: compounds 3, 2 and 4 (each within the scatter of the next). At a limit, above all of these: compound 1.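

In this assay, among the compounds shown here, the change from propyl to methyl on a saturated chain carbon bound to an aromatic carbon gives the first direct reading at this position: an at least 1.0-fold lower number from compound 1 to compound 4 (0.00 log units; that floor lies within the scatter). Compound 4, at 98700 nM, does give this position a real number from which later comparisons can start. Compound 1 stands at a limit of the assay and not at a number: the limit of > 100000 nM in this assay, at which 1 of the 4 values shown sits.

The step is therefore only a floor, and since that floor lies within the scatter, this pair cannot establish whether shortening the chain changes the read-out, or by how much.

The compounds shown leave open how the read-out would respond to other groups at this place, such as a butyl chain, a cyclopropyl ring, a primary amine or a carboxylic acid, any of which could show whether this position matters at all. They also leave open whether the same change from propyl to methyl would give a readable step in a pair where both partners carry true numbers, with neither one sitting at a limit.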